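Series notes: from compound 3 to compound 4

The source may report more compounds than this note shows. Statements on the series, on what has been measured and on what is new or still open speak of the compounds shown alone.

In a functional assay, read by fluorescence and spectrophotometry, with a stated time of 1 h (a higher number here means that more compound is needed for the effect, a lower number that less compound is needed), compound 3 (`CCCCCCCCCCS(=O)(=O)/C=C/c1ccc(O)c(O)c1`) gives 6800 nM, compound 1 (`C=CCCCCCCS(=O)(=O)/C=C/c1ccc(O)c(O)c1`) gives 6400 nM and compound 2 (`CCCCCCCS(=O)(=O)/C=C/c1ccc(O)c(O)c1`) gives 7100 nM. These three values lie within the scatter of one another, so compound 3 holds no distinct rank among them.

Compound 4 (`O=S(=O)(/C=C/c1ccc(O)c(O)c1)CCCCCCCCCCCO`) has hydroxymethyl in place of hydrogen on a saturated chain carbon, ten or more bonds along the chain from a sulfonyl sulfur.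

The measured steps that bear on this change are all changes on the same chain: a 1.1-fold higher number from compound 1 to compound 2 (0.05 log units; within the scatter), a 1.1-fold higher number from compound 1 to compound 3 (0.03 log units; within the scatter) and a 1.0-fold lower number from compound 2 to compound 3 (0.02 log units; within the scatter). Each lies within the scatter. None of them brings in hydroxymethyl, so this evidence is indirect and the range is kept wide.

The expected step in this assay is a 1.0-fold higher number from compound 3 to compound 4 (0.01 log units; within the scatter), with no change beyond the scatter anticipated. For compound 4 the estimated value is 7000 nM, with an expected range from 3500 nM to 14000 nM.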

Compound 4, half-maximal effective concentration: 22600 nM
Estimate against measurement, compound 4: 3.2-fold (0.51 log units) below; measured number outside the range, above it.
By their numbers in this assay, from the lowest: compounds 1, 3 and 2 (each within the scatter of the next); then compound 4.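

Working notes: in this assay, this chain end is the first place in the series where a change moves the number beyond the scatter (a 3.3-fold higher number from compound 3 to compound 4 (0.52 log units; beyond the scatter)). Within the data shown here, the two other steps to compound 4 read the same way (a 3.2-fold higher number from compound 2 to compound 4 (0.50 log units; beyond the scatter); a 3.5-fold higher number from compound 1 to compound 4 (0.55 log units; beyond the scatter)), whereas the all-carbon chain ends of compound 1, compound 2 and compound 3 stay within the scatter of one another, so the chain end is not indifferent to every change, and hydroxymethyl is the one entering group here that holds an oxygen atom. Nothing at hand accounts for this step.

Compound 4 alone carries this change, so the data do not separate the terminal hydroxyl from the added chain carbon. On these data alone, whether an amine or a carboxylic acid at the same place would raise the number as well, and whether a longer chain ending in hydroxyl would raise it further, stays open.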